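The source may report more compounds than this note shows. Statements on the series, on what has been measured and on what is new or still open speak of the compounds shown alone.

Measured so far in a functional assay on MCF7 cells (Homo sapiens) for cytotoxicity, read by sulforhodamine B assay, with a stated time of 48 h; on this read-out higher numbers stand for weaker inhibition of growth and lower numbers for stronger inhibition of growth:

compound 1, `CCOC(=O)c1[nH]c2ccccc2c1C(=O)c1cc(OC)c(OC)c(OC)c1N`, 480 nM
compound 2, `CCOC(=O)c1[nH]c2ccc(Cl)cc2c1C(=O)c1cc(OC)c(OC)c(OC)c1N`, 590 nM
compound 3, `COc1cc(Cc2c[nH]c3ccccc23)c(N)c(OC)c1OC`, 45000 nM

Compound 2 is compound 1 with one change: chloro in place of hydrogen on an aromatic carbon. The step in this assay is a 1.2-fold higher number from compound 1 to compound 2 (0.09 log units; within the scatter), so the two carry the same reading for practical purposes and no order between them is claimed.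

Compound 3 is built on a different core from compound 1; the difference between the two cores is not broken down here. In this assay compound 3 gives the highest number of the three, and the gaps to compound 2 and to compound 1 are both well beyond the scatter, so the core of compound 3 is clearly the less active of the two cores among these compounds.

Compound 4, `COc1cc(Cc2c[nH]c3ccc(Cl)cc23)c(N)c(OC)c1OC`, has not yet been measured. Relative to compound 3 it carries chloro in place of hydrogen on an aromatic carbon. This is the same change as that from compound 1 to compound 2, at the same kind of position on the fused ring system, only now on the core of compound 3. Among the measured compounds shown here, the expected step of a 1.2-fold higher number from compound 3 to compound 4 (0.06 log units; within the scatter) is taken to be about the size of a 1.2-fold higher number from compound 1 to compound 2 (0.09 log units; within the scatter), since that is the only measured instance of this change, with wider bounds because the core differs. Compound 4 is estimated at 52000 nM in this assay, with a range from 18000 nM to 150000 nM.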

Compound 4, concentration for 50% growth inhibition: "not active" (no number reported)
For compound 4 the study gives words and no number; there is nothing to compare the estimate with.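

In this assay, among the compounds shown here, compound 4 is reported only in words, as not active, so no step from compound 3 to compound 4 can be read. The compounds shown leave open whether chloro in place of hydrogen on the core of compound 3 matches the step seen on the other core, a 1.2-fold higher number from compound 1 to compound 2 (0.09 log units; within the scatter). No supporting data bear on this result.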